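A Chloropyridine Replaces the Difluoromethyl Aryl Group

The compounds below may be only part of what the source reports. "The series", "measured", "known", "first", "only" and "open" are said of these compounds alone.

In an ADME assay on microsomes from liver (Mus musculus) for metabolic stability (on this read-out lower numbers stand for slow clearance and higher numbers for fast clearance), compound 1 (`N#Cc1ccc(NC(=O)C(=O)N2CCC(c3ccnc4ccc(F)cc34)CC2)cc1`) gives 28 mL.min-1.g-1 and compound 2 (`O=C(Nc1ccc(C(F)F)cc1)C(=O)N1CCC(c2ccnc3ccc(F)cc23)CC1`) gives 76 mL.min-1.g-1 as the higher of the two numbers. Compound 3 (`O=C(Nc1ccc(Cl)cn1)C(=O)N1CCC(c2ccnc3ccc(F)cc23)CC1`) carries 5-chloropyridin-2-yl in place of 4-(difluoromethyl)phenyl on an amide-type nitrogen. Within the data shown here, the one measured step, a 2.7-fold higher number from compound 1 to compound 2 (0.43 log units; beyond the scatter) with difluoromethyl in place of cyano on an aromatic carbon, bears on this only in part, since compound 3 also loses that difluoromethyl group. In this assay the expected move is a 2.2-fold lower number from compound 2 to compound 3 (0.34 log units; beyond the scatter) and so a modest one toward a lower number. Compound 3 is estimated at 35 mL.min-1.g-1 (range 15 mL.min-1.g-1 to 80 mL.min-1.g-1).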

Compound 3, intrinsic clearance in microsomes: 112 mL.min-1.g-1
The estimate for compound 3 lay 3.2-fold (0.51 log units) below the measured number; measured number above the stated range.
By their numbers in this assay, from the lowest: compound 1; then compounds 2 and 3 (each within the scatter of the next).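

In this assay, putting 5-chloropyridin-2-yl in place of 4-(difluoromethyl)phenyl on the amide-type nitrogen gives a 1.5-fold higher number from compound 2 to compound 3 (0.17 log units; within the scatter), so this read-out does not tell the two groups apart. Against 4-cyanophenyl, the same group gives a 4.0-fold higher number from compound 1 to compound 3 (0.60 log units; beyond the scatter), which leaves compound 1 alone apart from the other two compounds. Nothing available here accounts for this result. Going by these compounds, what remains open is whether the nitrile or the ring carrying it sets compound 1 apart. A 5-cyanopyridin-2-yl or 4-chlorophenyl group on the same nitrogen would separate the two.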